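Pyrimidine in place of oxolane on the piperazine nitrogen

This account rests on a few compounds, and the source may have more. Where it says the series, first, only, none or still open, it means among the compounds named here.

Measured compounds:
- compound 1, `Cc1cccc2sc(NC(=O)CCN3CCN(C(C)C)CC3)nc12`: 1300 nM
- compound 2, `Cc1cccc2sc(NC(=O)CCN3CCN(CC4CCCO4)CC3)nc12`: 109 nM
- compound 3, `Cc1cccc2sc(NC(=O)CCN3CCN(c4ccncc4)CC3)nc12`: 9600 nM

These three compounds share one core and differ only in the group on an amine nitrogen in a ring. In an assay on membranes from brain for displacement of a labelled ligand from Sigma non-opioid intracellular receptor 1 (Cavia porcellus), read by scintillation counting, with a stated time of 120 min (a lower number here means a stronger inhibitor, a higher number a weaker inhibitor), compound 2 gives the lowest number of the three, with compound 1 nearest at a 12-fold lower number from compound 1 to compound 2 (1.08 log units; beyond the scatter) in reverse, and compound 3 furthest: an 88-fold higher number from compound 2 to compound 3 (1.94 log units; beyond the scatter).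

Compound 4, `Cc1cccc2sc(NC(=O)CCN3CCN(c4ncccn4)CC3)nc12`, is not yet measured. It differs from compound 2 in one place: pyrimidin-2-yl in place of (oxolan-2-yl)methyl on an amine nitrogen in a ring.

For the measured compounds named here, two measured steps bear on this change. Replacing the same (oxolan-2-yl)methyl by a six-membered aromatic ring, pyridin-4-yl, gave an 88-fold higher number from compound 2 to compound 3 (1.94 log units; beyond the scatter), and the step from the isopropyl parent to that aromatic ring gave a 7.4-fold higher number from compound 1 to compound 3 (0.87 log units; beyond the scatter). Both aromatic replacements weakened binding well beyond the scatter. Pyrimidin-2-yl is also a six-membered aromatic ring on this nitrogen, so for compound 4 the expected step is a 46-fold higher number from compound 2 to compound 4 (1.66 log units; beyond the scatter), a large weakening whose exact size remains uncertain.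

Compound 4 is therefore estimated at 5000 nM in this assay, with a likely range from 1500 nM to 15000 nM.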

Compound 4, inhibition constant: 505 nM
Estimate against measurement, compound 4: 9.9-fold (1.00 log units) above; the measured number lies below the stated range.
By their numbers in this assay, from the lowest: compound 2; then compound 4; then compound 1; then compound 3.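

In this assay, a six-membered aromatic ring on this amine nitrogen does not carry one fixed penalty, since changing pyridin-4-yl to pyrimidin-2-yl gives a 19-fold lower number from compound 3 to compound 4 (1.28 log units; beyond the scatter). The aromatic ring can even improve on the small alkyl group, with a 2.6-fold lower number from compound 1 to compound 4 (0.41 log units; beyond the scatter), so the weakening seen with pyridin-4-yl against isopropyl does not hold for every aromatic ring, and compound 4 goes against that trend. The (oxolan-2-yl)methyl group still keeps the lowest number of the four, as the replacement gives a 4.6-fold higher number from compound 2 to compound 4 (0.67 log units; beyond the scatter), but the loss from this change is much smaller than the one seen with pyridin-4-yl, and nothing measured here explains the difference between the two aromatic rings.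

The compounds shown cannot separate the effect of how many nitrogens the aromatic ring holds from the effect of where they sit, and a pyridin-2-yl or a plain phenyl ring on the same nitrogen would help to tell these apart. As far as these compounds go, it also remains open whether the low number of compound 2 depends on the ring oxygen, which a cyclopentylmethyl group in its place would test.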